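This account rests on a few compounds, and the source may have more. Where it says the series, first, only, none or still open, it means among the compounds named here.

Measured so far:
compound 1 `O=C(NCC1CCCCC1)N1C(=O)c2ccccc2S1(=O)=O`; in a physicochemical assay for pharmacokinetics (a higher number here means that the compound lasts longer, a lower number that the compound disappears faster), compound 1 gives > 166 h, a limit of the assay rather than a number.
compound 2 `O=C(NCc1cccs1)N1C(=O)c2ccccc2S1(=O)=O`; in this assay compound 2 gives > 166 h, likewise a limit of the assay.

Going by the values given here, compound 1 therefore stands at the upper limit of this assay, and the one further value shown sits at that same limit, (the limit of > 166 h in this assay, at which 2 of the 2 values shown sit). The step that the two limits leave unreadable from compound 1 to compound 2 is consequently not readable in size; the two limits hide whatever difference the thiophen-2-yl in place of cyclohexyl may have made.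

Compound 3 `COc1ccccc1CNC(=O)N1C(=O)c2ccccc2S1(=O)=O` differs from compound 1 as follows: 2-methoxyphenyl in place of cyclohexyl on a saturated chain carbon bound to an amide-type nitrogen. Among the compounds with values here, the only measured step that bears on this change is the one from compound 1 to compound 2, and its size cannot be read. No step beyond the scatter is known in either direction for this kind of change in this assay.

Because (the limit of > 166 h in this assay, at which 2 of the 2 values shown sit), compound 3 is expected to remain at the limit as well, with 200 h estimated and a range of 100 h to 500 h. The step that the limit leaves unreadable from compound 1 to compound 3 is thus expected to be no step beyond the scatter.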

Compound 3, half-life: > 166 h
Compound 3 gave a limit, no number; the forecaster's own chance of this, stated with the estimate: 80%; the middle value lies beyond the limit too.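

In this assay compound 3 gives > 166 h as a limit of the assay and not a number. The steps from compound 1 and from compound 2 to compound 3 therefore cannot be read: the limit of > 166 h in this assay, at which 3 of the 3 values shown sit. The compounds shown leave open whether cyclohexyl, thiophen-2-yl and 2-methoxyphenyl differ at all in this assay.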